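This account rests on a few compounds, and the source may have more. Where it says the series, first, only, none or still open, it means among the compounds named here.

Measured compounds and their values in a functional assay on SH-SY5Y cells (Homo sapiens) for antiproliferative activity, read by MTT assay, with a stated time of 72 h; on this read-out higher numbers stand for weaker inhibition and lower numbers for stronger inhibition:

Compound 1 `O=[N+]([O-])c1ccc(COc2ccc(Nc3ncnc4cc5c(cc34)OCCOCCO5)cc2)cc1`: 55200 nM
Compound 2 `FC(F)(F)c1ccc(COc2cccc(Nc3ncnc4cc5c(cc34)OCCOCCOCCO5)c2)cc1`: 20000 nM
Compound 3 `c1ccc(COc2ccccc2Nc2ncnc3cc4c(cc23)OCCOCCO4)cc1`: 93700 nM

Among these three numbers, compound 1 stands second highest. Its nearest neighbour is compound 3, whose number is higher by an amount that lies within the usual scatter of repeated measurements, so no order between compound 1 and compound 3 can be claimed. Compound 2 gives the lowest number, lower than that of compound 1 by an amount beyond the scatter. Among the measured compounds shown here, no pair of these measured compounds differs in a single place, so there is no measured step to use as a yardstick.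

Compound 4 `c1ccc(COc2ccc(Nc3ncnc4cc5c(cc34)OCCOCCO5)cc2)cc1` has not yet been measured. It differs from compound 1 by hydrogen in place of nitro on an aromatic carbon. For the measured compounds named here, with no comparable measured step available, the expectation is that this change gives no shift beyond the scatter in this assay in either direction. Compound 4 is therefore expected to give about 60000 nM, with a range from 20000 nM to 150000 nM. The expected step is a 1.1-fold higher number from compound 1 to compound 4 (0.04 log units; within the scatter).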

Compound 4, half-maximal inhibitory concentration: 39300 nM
For compound 4 the middle estimate is 1.5-fold (0.18 log units) above the measured one, within the range that was stated.
By their numbers in this assay, from the lowest: compounds 2, 4, 1 and 3 (each within the scatter of the next, the first and the last beyond it).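

In this assay, hydrogen in place of nitro gives a 1.4-fold lower number from compound 1 to compound 4 (0.15 log units; within the scatter), a step within the usual scatter of repeated measurements. Among the compounds shown here, compound 1 and compound 4 are the only measured pair here that differ in a single place, so this is the one direct reading of a change at this position, on an aromatic carbon para to a large group. On this read-out, 4-nitrobenzyl and benzyl cannot be told apart, and no measurement available here offers an explanation.

Going by these compounds, it remains open how other groups at this position, such as an amine, a carboxylic acid or a methoxy group, would compare with nitro and hydrogen. On these data alone, it is also open whether the same change would give a similarly small step on the core of compound 2 or compound 3.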